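Replacing the naphthyloxyacetyl arm of compound 1 with a methoxybenzyl propanoyl

A few compounds are considered here, and "the series" means these few. Any claim that something is new, unique, unknown or untested is made for them only; others in the source may bear on it.

Compound 1 `CC(C)C[C@H](N)c1cc(C(F)(F)F)ccc1N1CCN(C(=O)COc2ccc3ccccc3c2)CC1` sits second highest among the three numbers measured in an assay on HEK293 cells for displacement of a labelled ligand from Melanocortin receptor 4 (Homo sapiens) (on this read-out lower numbers stand for stronger inhibition and higher numbers for weaker inhibition), where compound 1 gives 2000 nM. Its nearest neighbour is compound 3 `Cc1ccc(OCC(=O)N2CCN(c3ccc(C(F)(F)F)cc3[C@@H](N)CC(C)C)CC2)cc1`, which in this assay gives 4400 nM; the step from the naphthalene to the smaller aromatic ring on the oxygen is a 2.2-fold higher number from compound 1 to compound 3 (0.34 log units; beyond the scatter). At the other extreme lies compound 2 `CC(C)C[C@H](N)c1cc(C(F)(F)F)ccc1N1CCN(C(=O)C(C)Cc2ccc(Cl)cc2)CC1`, which in this assay gives 47 nM, the step being a 43-fold lower number from compound 1 to compound 2 (1.63 log units; beyond the scatter).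

Compound 4 `COc1ccc(CC(C)C(=O)N2CCN(c3ccc(C(F)(F)F)cc3[C@@H](N)CC(C)C)CC2)cc1` differs from compound 1 as follows: 1-(4-methoxybenzyl)ethyl in place of ((naphthalen-2-yl)oxy)methyl on a carbonyl carbon. Among the measured compounds shown here, the change that bears most directly on it is the one to compound 2, since compound 4 shares with compound 2 the 1-benzylethyl arrangement on the carbonyl carbon and differs only in the substituent on the aromatic ring. The step from compound 2 to compound 3, a 94-fold higher number from compound 2 to compound 3 (1.97 log units; beyond the scatter), confirms how strongly this arm on the carbonyl carbon moves the numbers in this assay.

He therefore expects a large fall in the number for compound 4, though somewhat smaller than that seen for compound 2, because a 43-fold lower number from compound 1 to compound 2 (1.63 log units; beyond the scatter) was measured with a chlorine-bearing ring while the methoxy version is untested; the expected step is an 18-fold lower number from compound 1 to compound 4 (1.26 log units; beyond the scatter). His estimate for compound 4 in this assay is 110 nM, within a range of 30 nM to 400 nM.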

Compound 4, inhibition constant: 120 nM
For compound 4 the middle estimate is 1.1-fold (0.04 log units) below the measured one; measured number inside the range.
By their numbers in this assay, from the lowest: compound 2; then compound 4; then compound 1; then compound 3.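

In this assay the 1-(4-methoxybenzyl)ethyl arm on the carbonyl carbon gives a 17-fold lower number from compound 1 to compound 4 (1.22 log units; beyond the scatter) and a 37-fold lower number from compound 3 to compound 4 (1.56 log units; beyond the scatter) so the large drop first seen with the chlorine-bearing arm of compound 2 is not tied to chlorine and also holds with a methoxy-bearing ring. The ring substituent still counts: methoxy in place of chloro gives a 2.6-fold higher number from compound 2 to compound 4 (0.41 log units; beyond the scatter) and this modest step is smaller than either step from the aryloxy arms, so among these four compounds the type of arm moves the number more than the tested substituent change does. Nothing at hand explains these differences.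

The 1-benzylethyl and aryloxymethyl arms differ in more than one feature, so these compounds do not separate the effect of the oxygen in the chain from that of the branched carbon. From the compounds shown here alone, it also remains open where a hydroxy group, a nitrile or a dimethylamino group on the aromatic ring of the 1-benzylethyl arm would fall relative to chloro and methoxy.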